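Adding a Pentyl Chain to Compound 2

The source may report more compounds than this note shows. Statements on the series, on what has been measured and on what is new or still open speak of the compounds shown alone.

In a functional assay on M21 cells (Homo sapiens) for antiproliferative activity, read by sulforhodamine B assay, with a stated time of 48 h (a higher number here means a weaker inhibitor, a lower number a stronger inhibitor), compound 2 `O=C1NCCN1c1ccc(S(=O)(=O)Nc2ccccc2)cc1` gives 200 nM and holds the second highest of three numbers. Compound 1 `CCc1ccc(NS(=O)(=O)c2ccc(N3CCNC3=O)cc2)cc1` stands higher (480 nM), and compound 3 `O=C1NCCN1c1ccc(S(=O)(=O)Nc2cccc(Br)c2)cc1` stands lower (59 nM). The unmeasured compound 4 `CCCCCc1ccc(NS(=O)(=O)c2ccc(N3CCNC3=O)cc2)cc1` differs from compound 2 by one change, pentyl in place of hydrogen on an aromatic carbon, para to a large group pentyl in place of hydrogen on an aromatic carbon on that ring.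

The closest evidence is the step that removes ethyl, a 2.4-fold lower number from compound 1 to compound 2 (0.38 log units; beyond the scatter) here. Read backwards, it shows that the ethyl compound carries the higher number. The step that adds bromo, a 3.4-fold lower number from compound 2 to compound 3 (0.53 log units; beyond the scatter) in this case, runs the other way, so compound 3 goes against any simple rule that a new group raises the number. It involves a different group, however, and bears less directly on a carbon chain. No chain longer than ethyl has been measured, so the size of the change remains uncertain.

A step towards a higher number, somewhat larger than the ethyl step, is expected (a 4.0-fold higher number from compound 2 to compound 4 (0.60 log units; beyond the scatter)). In this assay the estimated value for compound 4 is 800 nM with 300 nM to 2500 nM as its expected range.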

Compound 4, half-maximal inhibitory concentration: 870 nM
The estimate for compound 4 lay 1.1-fold (0.04 log units) below the measured number; the range from low to high includes it.
By their numbers in this assay, from the lowest: compound 3; then compound 2; then compounds 1 and 4 (each within the scatter of the next).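

In this assay the pentyl chain gives a 4.4-fold higher number from compound 2 to compound 4 (0.64 log units; beyond the scatter) and so shows that the rise first seen with ethyl, at this place para to a large group, also holds for a chain of five carbons. Going from the ethyl chain to the pentyl chain gives a 1.8-fold higher number from compound 1 to compound 4 (0.26 log units; within the scatter) but this lies within the scatter, so the two chains cannot be told apart here and the added length shows no clear further effect on the number. Both chains therefore stand on the same side of compound 2, whereas compound 3, with its bromo group, goes against any rule that an added group raises the number.

Nothing among the data shown accounts for the higher number that comes with these chains. Still open, going by these compounds, is how the number behaves with a chain longer than pentyl, or with a chain of similar length that ends in an amine or a carboxylic acid, and whether such groups at this place would keep the number as high as in the ethyl and pentyl compounds.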